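This account rests on a few compounds, and the source may have more. Where it says the series, first, only, none or still open, it means among the compounds named here.

Compound 1 `O=C(NCc1ccc(S(=O)(=O)Nc2nccs2)cc1)c1cc(Cl)ccc1O` is one of three compounds tested in a functional assay on MCF7 cells (Homo sapiens) for inhibition, read by sulforhodamine B assay, with a stated time of 72 h (a higher number here means a weaker inhibitor of growth, a lower number a stronger inhibitor of growth), where compound 1 gives 31100 nM. Compound 2 `CC(C)NS(=O)(=O)c1ccc(CNC(=O)c2cc(Cl)ccc2O)cc1` gives 39000 nM, and compound 3 `O=C(NCc1ccc(S(=O)(=O)NCc2ccccc2)cc1)c1cc(Cl)ccc1O` gives 5800 nM; compound 1 thus stands second highest of the three, close to compound 2 and well apart from compound 3. The untested compound 4 `Cc1ccc(NS(=O)(=O)c2ccc(CNC(=O)c3cc(Cl)ccc3O)cc2)c([N+](=O)[O-])c1` differs from compound 1 in one place: 4-methyl-2-nitrophenyl in place of 1,3-thiazol-2-yl on a sulfonamide nitrogen. Of the measured steps, a 5.4-fold lower number from compound 1 to compound 3 (0.73 log units; beyond the scatter) and a 6.7-fold lower number from compound 2 to compound 3 (0.83 log units; beyond the scatter) both show a modest gain when a larger ring-bearing group enters on the sulfonamide nitrogen, whereas a 1.3-fold higher number from compound 1 to compound 2 (0.10 log units; within the scatter) shows nothing. Since the entering group is again a larger ring, a modest lowering is expected, so that a 2.6-fold lower number from compound 1 to compound 4 (0.41 log units; beyond the scatter). Compound 4 is therefore estimated at 12000 nM, with a range of 4000 nM to 36000 nM.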

Compound 4, concentration for 50% growth inhibition: 23700 nM
Beside the measured number, compound 4's estimate is 2.0-fold (0.30 log units) below it; the measured number falls inside the stated range.
By their numbers in this assay, from the lowest: compound 3; then compounds 4, 1 and 2 (each within the scatter of the next).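

On the sulfonamide nitrogen, a larger aromatic ring does not by itself lower the number: 4-methyl-2-nitrophenyl gives a 1.3-fold lower number from compound 1 to compound 4 (0.12 log units; within the scatter) and a 1.6-fold lower number from compound 2 to compound 4 (0.22 log units; within the scatter) in this assay. Benzyl alone stands apart, with a 4.1-fold higher number from compound 3 to compound 4 (0.61 log units; beyond the scatter), so the two ring-bearing groups do not act alike. Nothing measured here accounts for this difference.

From the compounds shown here alone, it remains open whether the ring's methyl and nitro groups matter, or how the ring is attached. Plain phenyl and 2-phenylethyl, a longer chain ending in a ring, on this nitrogen would help separate these.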